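Methoxycarbonyl for dimethylaminoethyl on a weakly active scaffold

A few compounds are considered here, and "the series" means these few. Any claim that something is new, unique, unknown or untested is made for them only; others in the source may bear on it.

This account concerns a small set of amide-bearing compounds tested in a functional assay on HCT-116 cells (Homo sapiens) for cytotoxicity, read by MTT assay, with a stated time of 72 h; a higher number here means a weaker inhibitor, a lower number a stronger inhibitor. Compound 1, `CN(C)CCCNc1c(C(=O)NCc2ccc(F)cc2)nc(Br)c2cccnc12`, is the starting point. In this assay compound 1 reaches only a limit rather than a number, giving > 10000 nM; this is the situation described by the limit of > 10000 nM in this assay, at which 1 of the 3 values shown sits. Two related compounds share the same amide arm on a differently decorated core. Compound 2, `C[C@@H](CO)Nc1nc(C(=O)NCc2ccc(F)cc2)c(O)c2ncccc12`, gives "not determined" (no result reported) in this assay. Compound 3, `O=CNCCCCCCNc1nc(C(=O)NCc2ccc(F)cc2)c(O)c2ncccc12`, gives 6000 nM in this assay. Because no two of these compounds differ in a single place, no measured step connects them, and compound 1 is known only by its limit.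

The unmeasured compound 4, `COC(=O)CNc1c(C(=O)NCc2ccc(F)cc2)nc(Br)c2cccnc12`, differs from compound 1 by methoxycarbonyl in place of 2-(dimethylamino)ethyl on a saturated chain carbon bound to a nitrogen on an aromatic ring. Going by the values given here, with compound 1 sitting at a limit, the data offer no measured step from which to read the direction of this change. The step from compound 1 to compound 4 is therefore expected to be a step that the limit leaves unreadable from compound 1 to compound 4, lying within the scatter rather than a real shift. Compound 4 is estimated at 15000 nM, with a range from 5000 nM to 50000 nM.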

Compound 4, half-maximal inhibitory concentration: > 10000 nM
Compound 4 ended at the assay's limit (the forecaster's own chance of this, stated with the estimate: 70%); the middle value does not contradict the limit.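

Compound 1 and compound 4 both rest at a limit in this assay, so no step between them can be read: the limit of > 10000 nM in this assay, at which 2 of the 4 values shown sit.

The compounds shown leave open whether methoxycarbonyl in place of 2-(dimethylamino)ethyl shifts activity on the core of compound 1 at all.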